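From compound 2 to compound 3: swapping a carbonyl substituent

A few compounds are considered here, and "the series" means these few. Any claim that something is new, unique, unknown or untested is made for them only; others in the source may bear on it.

Values in an in vitro ADME assay on microsomes (Mus musculus) for metabolic stability; on this read-out lower numbers stand for a shorter-lived compound and higher numbers for a longer-lived compound:
Compound 1 `CC[C@H](N)C(=O)N1CCc2c(C)c3c(n2-c2ccc(C(N)=O)c(c2)N[C@@H](C)[C@H](C)C1)CC(C)(C)CC3=O`: 0.383 h
Compound 2 `Cc1c2c(n3c1CCN(C(=O)C1(N)CC1)C[C@@H](C)[C@H](C)Nc1cc-3ccc1C(N)=O)CC(C)(C)CC2=O`: > 0.5 h (a limit)

Compound 2 stands at the limit of > 0.5 h in this assay, at which 1 of the 2 values shown sits. Compound 2 reports > 0.5 h, which is a limit and not a number.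

The next structure is compound 3 `Cc1c2c(n3c1CCN(C(=O)[C@H](C)O)C[C@@H](C)[C@H](C)Nc1cc-3ccc1C(N)=O)CC(C)(C)CC2=O`, which has not yet been measured in this assay. The change is 1-hydroxyethyl in place of 1-aminocyclopropyl on a carbonyl carbon.

For the measured compounds named here, one measured step bears on this change: an at least 1.3-fold higher number from compound 1 to compound 2 (0.11 log units; that floor lies within the scatter). That step also falls on a carbonyl carbon, but it gives only a floor and involves a different pair of groups, so it fixes neither a size nor a direction for the new change. Going by the values given here, compound 1 gives 0.383 h, the only true number available, and the expectation stays close to it. No step beyond the scatter is expected. The expected step is an at least 1.1-fold lower number from compound 2 to compound 3 (0.04 log units; that floor lies within the scatter). For compound 3 the estimate is 0.45 h, with an expected range from 0.22 h to 0.9 h.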

Compound 3, half-life: > 0.5 h
Compound 3 gave a limit, no number; the forecaster's own chance of this, stated with the estimate: 40%; middle value at least 1.1-fold (0.04 log units) away from the limit.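

In this assay compound 3 reports > 0.5 h, which is a limit and not a number. On the carbonyl carbon, then, a 1-hydroxyethyl group with no ring and with oxygen in place of nitrogen also reaches the limit, so a ring and an amine on this substituent are not both needed to get there: the limit of > 0.5 h in this assay, at which 2 of the 3 values shown sit.

For the compounds shown here, the one readable comparison gives an at least 1.3-fold higher number from compound 1 to compound 3 (0.11 log units; that floor lies within the scatter), the same floor as the step to compound 2, so it shows no change beyond the scatter, and the step between the two compounds at the limit cannot be read.

The compounds shown leave open how far the true half-lives of compound 2 and compound 3 lie beyond the limit, and whether 1-hydroxyethyl and 1-aminocyclopropyl differ at all in this read-out. They also leave open how the opposite stereocentre of the 1-hydroxyethyl group, a carboxylic acid or a longer chain ending in a hydroxyl on the same carbonyl carbon would read in this assay.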